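Working notes: cyano in place of trifluoromethyl

A few compounds are considered here, and "the series" means these few. Any claim that something is new, unique, unknown or untested is made for them only; others in the source may bear on it.

In a functional assay on HepG2 cells (Homo sapiens) for cytotoxicity, read by MTT assay, with a stated time of 24 h (a lower number here means a stronger inhibitor, a higher number a weaker inhibitor), compound 1 (`CN1C/C(=C\c2ccncc2)C(=O)/C(=C/c2ccccc2F)C1`) gives 4600 nM and compound 2 (`CN1C/C(=C\c2ccncc2)C(=O)/C(=C/c2ccc(F)cc2Br)C1`) gives 9200 nM while compound 3 (`CN1C/C(=C\c2ccncc2)C(=O)/C(=C/c2ccc(C(F)(F)F)cc2)C1`) gives 8200 nM on the same read-out. Compound 3 lies within the scatter of both compound 1 and compound 2. Compound 4 (`CN1C/C(=C\c2ccncc2)C(=O)/C(=C/c2ccc(C#N)cc2)C1`) carries cyano in place of trifluoromethyl on an aromatic carbon, para to a large group (cyano in place of trifluoromethyl on an aromatic carbon). Within the data shown here, no measured compound carries cyano, and the only measured step in one place is a change of phenyl substituents. Because this step (a 2.0-fold higher number from compound 1 to compound 2 (0.30 log units; within the scatter)) stays within the scatter, no step beyond the scatter is expected. The expected step (a 1.2-fold lower number from compound 3 to compound 4 (0.07 log units; within the scatter)) is correspondingly small. Compound 4 is estimated at 7000 nM (expected range 3000 nM to 16000 nM).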

Compound 4, half-maximal inhibitory concentration: 13900 nM
Compound 4: the middle estimate sits 2.0-fold (0.30 log units) below what was measured, within the range that was stated.
By their numbers in this assay, from the lowest: compounds 1, 3, 2 and 4 (each within the scatter of the next, the first and the last beyond it).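

Cyano in place of trifluoromethyl on this aromatic carbon, para to a large group, leaves this assay within the scatter (a 1.7-fold higher number from compound 3 to compound 4 (0.23 log units; within the scatter)), and the exchange of 2-bromo-4-fluorophenyl for 4-cyanophenyl does the same (a 1.5-fold higher number from compound 2 to compound 4 (0.18 log units; within the scatter)). Among these compounds, the exchange of 2-fluorophenyl for 4-cyanophenyl gives the one step beyond the scatter, a modest one (a 3.0-fold higher number from compound 1 to compound 4 (0.48 log units; beyond the scatter)). No evidence bears on the origin of these steps. Open, as far as these compounds go, is whether an amine or a carboxylic acid on this aromatic carbon would stay within the scatter of compound 3.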